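Compound 4: a new group on the amide-type nitrogen

The source may report more compounds than this note shows. Statements on the series, on what has been measured and on what is new or still open speak of the compounds shown alone.

Of the compounds shown here, three sharing one core have been tested in a functional assay on Shh Light II cells (Mus musculus) for inhibition, read by a luciferase reporter; a higher number here means a weaker inhibitor, a lower number a stronger inhibitor. Compound 1 (`O=C(NC1CC[S+]([O-])CC1)N1CCC(c2nc(-c3ccc4ccccc4n3)no2)CC1`) gives 850 nM, compound 2 (`N#Cc1ccccc1NC(=O)N1CCC(c2nc(-c3ccc4ccccc4n3)no2)CC1`) gives 190 nM, and compound 3 (`O=C(Nc1cccnc1Cl)N1CCC(c2nc(-c3ccc4ccccc4n3)no2)CC1`) gives 1600 nM. Compound 3 therefore sits level with one relative and clearly apart from the other: the data show a 1.9-fold higher number from compound 1 to compound 3 (0.27 log units; within the scatter), but also an 8.4-fold higher number from compound 2 to compound 3 (0.93 log units; beyond the scatter).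

Compound 4 (`Cc1noc(C)c1NC(=O)N1CCC(c2nc(-c3ccc4ccccc4n3)no2)CC1`) alters the same place on the amide-type nitrogen, with 3,5-dimethyl-1,2-oxazol-4-yl in place of 2-chloropyridin-3-yl on an amide-type nitrogen.

Among the measured compounds shown here, no tested compound carries the new group, so the earlier steps offer only a guide to size. Changes at this place have produced a 4.5-fold lower number from compound 1 to compound 2 (0.65 log units; beyond the scatter) at the larger end of what is seen here, and a 1.9-fold higher number from compound 1 to compound 3 (0.27 log units; within the scatter) at the smaller end. Compound 1 at 850 nM and compound 2 at 190 nM suggest a lean toward lower numbers. The expected change is small and may not clear the scatter: a 1.8-fold lower number from compound 3 to compound 4 (0.25 log units; within the scatter). For compound 4 the estimated value is 900 nM, with an expected range of 250 nM to 3000 nM.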

Compound 4, half-maximal inhibitory concentration: 3000 nM
Compound 4: middle estimate off by 3.3-fold (0.52 log units), on the low side, and the stated range covers the measured number.
By their numbers in this assay, from the lowest: compound 2; then compounds 1, 3 and 4 (each within the scatter of the next, the first and the last beyond it).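

Two different aromatic groups, 2-chloropyridin-3-yl and 3,5-dimethyl-1,2-oxazol-4-yl, read alike in this assay, with a 1.9-fold higher number from compound 3 to compound 4 (0.27 log units; within the scatter). The new group also opens the widest gap yet seen at this place, a 16-fold higher number from compound 2 to compound 4 (1.20 log units; beyond the scatter), and it stands clearly apart from the non-aromatic sulfur-containing ring, a 3.5-fold higher number from compound 1 to compound 4 (0.55 log units; beyond the scatter), a separation the 2-chloropyridin-3-yl group did not reach. Nothing available here explains these gaps.

It remains open whether the low number of 2-cyanophenyl belongs to the nitrile or to the ring that carries it, since no plain phenyl group or 2-chlorophenyl group appears among these compounds. Going by these compounds, how a simple open chain such as n-butyl on the amide-type nitrogen would compare also stays unknown.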